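The source may report more compounds than this note shows. Statements on the series, on what has been measured and on what is new or still open speak of the compounds shown alone.

Compound 1 `COc1ccc(/C=C2/N=C(c3ccccc3)N(C(=O)c3ccc(Cl)cc3)NC2=O)cc1` and compound 2 `O=C1NN(C(=O)c2ccc(Cl)cc2)C(c2ccccc2)=N/C1=C/c1ccccc1` share one core and differ only at a single aromatic carbon. In a functional assay on the whole organism (strain albino) with Mus musculus as the target, with a stated time of 0.5 h (a lower number here means that less compound is needed, a higher number that more compound is needed for the effect), compound 1 gives 100 mg/kg, and compound 2 gives 100 mg/kg. The step of no change at the digits printed from compound 1 to compound 2 (within the scatter) shows that removing the methoxy left the dose unchanged within the scatter, so compound 2 stands level with compound 1 at the digits shown, with no other measured neighbour.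

Compound 3 `Cc1ccc(/C=C2/N=C(c3ccccc3)N(C(=O)c3ccc(Cl)cc3)NC2=O)cc1` differs from compound 2 in one place: methyl in place of hydrogen on an aromatic carbon. Among the measured compounds shown here, only one measured step bears on a change at this aromatic carbon, namely no change at the digits printed from compound 1 to compound 2 (within the scatter), and it was flat. With nothing in the data pointing either way, a further small group at this carbon is expected to give no step beyond the scatter, that is no change at the digits printed from compound 2 to compound 3 (within the scatter). Compound 3 is therefore estimated at 100 mg/kg, with a range from 50 mg/kg to 200 mg/kg.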

Compound 3, dose for half-maximal effect: 100 mg/kg
For compound 3 middle estimate and measured number coincide at the digits printed; measured number inside the range.
By their numbers in this assay, from the lowest: compounds 1, 2 and 3 (each within the scatter of the next).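

Adding a methyl group at this aromatic carbon gives no change at the digits printed from compound 2 to compound 3 (within the scatter) in this assay, so the first carbon substituent tried in place of hydrogen behaves as the methoxy group did. Exchanging one substituent directly for the other gives no change at the digits printed from compound 1 to compound 3 (within the scatter), which means that hydrogen, methyl and methoxy at this carbon cannot be told apart by this read-out. Nothing in the available data offers a reason for this flat result.

The compounds shown leave open whether an amine, a carboxylic acid, a chlorine atom or a longer chain at this carbon would shift the dose beyond the scatter. They also leave open whether any change elsewhere on the shared core would move the dose, since all three compounds differ only at this one aromatic carbon.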